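A few compounds are considered here, and "the series" means these few. Any claim that something is new, unique, unknown or untested is made for them only; others in the source may bear on it.

In an assay (Rattus norvegicus) for inhibition of Fatty-acid amide hydrolase 1 (Homo sapiens) (a lower number here means a stronger inhibitor, a higher number a weaker inhibitor), compound 3 `NC(=O)c1cccc(-c2cnc(C(=O)CCCCCCc3ccccc3)o2)c1` gives 6 nM, the lowest of the three numbers on hand; compound 1 `NS(=O)(=O)c1ccccc1-c1cnc(C(=O)CCCCCCc2ccccc2)o1` gives 1500 nM and compound 2 `O=C(CCCCCCc1ccccc1)c1ncc(-c2ccccc2C(=O)C(F)(F)F)o1` gives 5000 nM. Compound 4 `Cc1ccc(-c2cnc(C(=O)CCCCCCc3ccccc3)o2)nc1` is not yet measured and differs from compound 3 in one place: 5-methylpyridin-2-yl in place of 3-carbamoylphenyl on an aromatic carbon. Among the measured compounds shown here, no measured step exchanges the whole group on that carbon. For the measured compounds named here, the only known step, a 3.3-fold higher number from compound 1 to compound 2 (0.52 log units; beyond the scatter), changes a substituent on that ring, and the gap from compound 1 to compound 3 shows how strongly the 3-carbamoylphenyl, with its one hydrogen-bond donor, lowers the number. Losing that donor is expected to cost, with a step of a 20-fold higher number from compound 3 to compound 4 (1.30 log units; beyond the scatter) toward a higher number. Compound 4 is expected at 120 nM, within 15 nM to 900 nM.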

Compound 4, inhibition constant: 2.8 nM
Beside the measured number, compound 4's estimate is 43-fold (1.63 log units) above it; measured number outside the range, below it.
By their numbers in this assay, from the lowest: compound 4; then compound 3; then compound 1; then compound 2.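

In this assay the exchange of 3-carbamoylphenyl for 5-methylpyridin-2-yl gives a 2.1-fold lower number from compound 3 to compound 4 (0.33 log units; beyond the scatter) and shows that a low number at this position does not depend on the hydrogen-bond donor of the amide. A six-membered aromatic ring with a ring nitrogen and no hydrogen-bond donor serves here as well as the carbamoyl-bearing phenyl or better. No measurement on hand accounts for this step.

As far as these compounds go, whether the methyl or the ring nitrogen of 5-methylpyridin-2-yl sets the number remains open, and pyridin-2-yl without the methyl would separate the two. Also open, from the compounds shown here alone, is how an amine or a carboxylic acid in place of that methyl would read in this assay.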